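A few compounds are considered here, and "the series" means these few. Any claim that something is new, unique, unknown or untested is made for them only; others in the source may bear on it.

Measured so far:
- compound 1, `CC(C)Sc1n[nH]c(-n2[se]c3ccccc3c2=O)n1`: 6010 nM
- compound 2, `O=c1c2ccccc2[se]n1-c1nc(SCc2ccccc2)n[nH]1`: 32000 nM
- compound 3, `Cc1cccc(CSc2n[nH]c(-n3[se]c4ccccc4c3=O)n2)c1`: 9040 nM

In a functional assay on SMMC-7721 cells (Homo sapiens) for antiproliferative activity, read by CCK-8 assay, with a stated time of 48 h (on this read-out lower numbers stand for stronger inhibition and higher numbers for weaker inhibition), compound 3 stands second highest of the three numbers, with compound 1 nearest (a 1.5-fold higher number from compound 1 to compound 3 (0.18 log units; within the scatter)) and compound 2 furthest (a 3.5-fold lower number from compound 2 to compound 3 (0.55 log units; beyond the scatter)).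

Compound 4, `CCCCSc1n[nH]c(-n2[se]c3ccccc3c2=O)n1`, is not yet measured. Its change from compound 3 is propyl in place of 3-methylphenyl on a saturated chain carbon bound to a sulfur. For the measured compounds named here, two measured steps bear on it. a 1.5-fold higher number from compound 1 to compound 3 (0.18 log units; within the scatter) shows that exchanging a small alkyl on the sulfur for a 3-methylbenzyl moves the number only within the scatter. a 5.3-fold higher number from compound 1 to compound 2 (0.73 log units; beyond the scatter) shows that a benzyl without the methyl gives a modestly higher number than isopropyl. Compound 4 carries a butyl, an alkyl chain like the isopropyl of compound 1, so the return from 3-methylbenzyl to alkyl is expected to undo the small step from compound 1 to compound 3, giving a step no larger than the scatter, if anything toward a lower number.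

For compound 4 the number in this assay is estimated at 6500 nM, with a range of 3000 nM to 15000 nM, which means an expected step of a 1.4-fold lower number from compound 3 to compound 4 (0.14 log units; within the scatter).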

Compound 4, half-maximal inhibitory concentration: 16800 nM
Beside the measured number, compound 4's estimate is 2.6-fold (0.41 log units) below it; the whole stated range lies below it.
By their numbers in this assay, from the lowest: compounds 1, 3, 4 and 2 (each within the scatter of the next, the first and the last beyond it).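

In this assay, the alkyl groups on the sulfur do not behave as one class: butyl in place of isopropyl gives a modest step beyond the scatter (a 2.8-fold higher number from compound 1 to compound 4 (0.45 log units; beyond the scatter)). The aromatic ring of the substituent, by contrast, is not needed for values in this range, since both propyl in place of 3-methylphenyl (a 1.9-fold higher number from compound 3 to compound 4 (0.27 log units; within the scatter)) and propyl in place of phenyl (a 1.9-fold lower number from compound 2 to compound 4 (0.28 log units; within the scatter)) stay within the scatter. No measurement at hand accounts for these steps.

Still open, from the compounds shown here alone, is whether a longer chain such as hexyl on the sulfur continues the step seen with butyl, or whether a smaller group such as ethyl stays with isopropyl. Going by these compounds, the effect of a terminal amine or carboxylic acid on the chain also remains open.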